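The compounds below may be only part of what the source reports. "The series", "measured", "known", "first", "only" and "open" are said of these compounds alone.

In a functional assay on OVCAR-3 cells (Homo sapiens) for inhibition, read by MTT assay, with a stated time of 24 h (a higher number here means a weaker inhibitor, a lower number a stronger inhibitor), compound 2, `O=[N+]([O-])c1ccc(/C=C/[C@@H]2CCCCN2)cc1`, gives 1.02 ug/mL, the lowest of the two numbers recorded so far. For the measured compounds named here, the only other measured compound is compound 1, `CCc1ccc(/C=C/[C@@H]2CCCCN2)cc1`, which in this assay gives 5.07 ug/mL; the step between them was a 5.0-fold lower number from compound 1 to compound 2 (0.70 log units; beyond the scatter), and this is the one measured step that bears on the next comparison. The next compound is compound 3, `COc1ccc(/C=C/[C@@H]2CCCCN2)cc1`. The change is methoxy in place of nitro on an aromatic carbon, which removes the group that marked the stronger of the two measured compounds and puts in something not seen in either. As far as these compounds go, since the earlier step shows nitro in place of ethyl giving a lower number, taking nitro away again is expected to push the number back up, though the methoxy itself is untested here, so the size of the step is uncertain. For compound 3 the step is expected to be a 3.4-fold higher number from compound 2 to compound 3 (0.54 log units; beyond the scatter). The estimate for compound 3 in this assay is 3.5 ug/mL, with a range from 1.2 ug/mL to 10 ug/mL.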

Compound 3, half-maximal inhibitory concentration: 3.31 ug/mL
For compound 3 the middle estimate is 1.1-fold (0.02 log units) above the measured one, within the range that was stated.
By their numbers in this assay, from the lowest: compound 2; then compounds 3 and 1 (each within the scatter of the next).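

In this assay, methoxy in place of nitro on this aromatic carbon gives a 3.2-fold higher number from compound 2 to compound 3 (0.51 log units; beyond the scatter), so the lower number of compound 2 does not return with this second replacement for nitro. Methoxy in place of ethyl at the same carbon gives a 1.5-fold lower number from compound 1 to compound 3 (0.19 log units; within the scatter), which lies within the scatter, so this assay does not separate these two groups here and, among the three groups tested at this place, only nitro stands apart. No measurement available here explains why nitro stands apart from methoxy and ethyl.

As far as these compounds go, it remains open whether the lower number is particular to nitro or is shared by other groups on this carbon, such as a nitrile or trifluoromethyl. Equally open, from the compounds shown here alone, is whether an amine, a carboxylic acid or a longer chain in this place would fall with compound 2 or with compounds 1 and 3.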